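The source may hold more compounds than are shown below. What is called first, only, known or untested is meant among the compounds shown, and "the series" means these compounds.

The measured compounds are compound 1 `Cc1ccc2ncc(S(=O)(=O)c3ccc(C)c(C)c3)c(N3CCC(C)CC3)c2c1` with 90%, compound 2 `Cc1ccc2ncc(S(=O)(=O)c3ccc(C)c(Cl)c3)c(N3CCC(C)CC3)c2c1` with 91%, and compound 3 `Cc1ccc(S(=O)(=O)c2cnc3ccc(Cl)cc3c2N2CCC(C)CC2)cc1` with 95%, all in an assay on isolated protein for displacement of a labelled ligand from metabotropic glutamate receptor 5 (Homo sapiens), with a stated time of 60 min, tested at 1 uM; a lower number here means less inhibition, a higher number more inhibition at the concentration tested (going by the name of the read-out).

Compound 1 and compound 2 share a core and differ only at one aromatic carbon, described as methyl in place of chloro on an aromatic carbon. In this assay this change produced a number 1 percentage points lower from compound 2 to compound 1 (within the scatter), a step that sits within the scatter of the method, so the two compounds cannot be told apart by this read-out. Compound 3 carries a different core; the difference between the two cores is not broken down here. Its number in this assay is within the scatter of both compound 1 and compound 2, so no order among the three can be claimed.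

Compound 4 `Cc1ccc(S(=O)(=O)c2cnc3ccc(C)cc3c2N2CCC(C)CC2)cc1` has not yet been measured. It stands to compound 3 as compound 1 stands to compound 2, by the change (methyl in place of chloro on an aromatic carbon). The surroundings differ: in compound 4 the changed carbon belongs to a six-membered aromatic ring of carbon only that is part of a fused system of two rings, meta and para to a fused ring, whereas in compound 1 it is ortho to a methyl group and meta to a large group; it is therefore the same kind of change, not the same change. Because a number 1 percentage points lower from compound 2 to compound 1 (within the scatter) lies within the scatter, compound 4 is expected to give about 93% in this assay, which means an expected step of a number 2 percentage points lower from compound 3 to compound 4 (within the scatter). The estimated range for compound 4 runs from 85% to 98%.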

Compound 4, a percentage reported as inhibition, at one concentration (the size of the read-out at that concentration, not a potency): 82%
Beside the measured number, compound 4's estimate is 11 percentage points above it; the measured number lies below the stated range.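

Carrying methyl in place of chloro onto the core of compound 3 gave a number 13 percentage points lower from compound 3 to compound 4 (beyond the scatter) in this assay, so on this core the change can be read, whereas on the core of compound 2 it could not. Even so, the two steps cannot be called different, and the series therefore shows neither that the change carries over unaltered nor that the core governs its size: the same change on two cores in this assay, a number 1 percentage points lower (within the scatter) from compound 2 to compound 1 and a number 13 percentage points lower (beyond the scatter) from compound 3 to compound 4, 12 percentage points apart, within the scatter of two such steps Hydrogen in place of chloro gave a number 9 percentage points lower from compound 2 to compound 4 (within the scatter) and hydrogen in place of methyl gave a number 8 percentage points lower from compound 1 to compound 4 (within the scatter), so neither of these two steps separates the compounds, and with only one pair of steps on two cores no rule for moving the change between cores can be drawn.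

The compounds shown leave open how other groups on this aromatic carbon, such as a methoxy group, a nitrile or an amine, would read in this assay, and whether a third core would bring the step closer to one of the two seen here. They also leave open how these compounds compare in potency, as each number is the size of the read-out at a single concentration.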